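This account rests on a few compounds, and the source may have more. Where it says the series, first, only, none or still open, it means among the compounds named here.

Measured so far:
compound 1, `COc1cc2ncnc(Nc3cccc(Br)c3)c2cc1OCCCCC(=O)Nc1ccc(S(N)(=O)=O)cc1`: 14900 nM
compound 2, `C#Cc1cccc(Nc2ncnc3ccc(NC(=S)Nc4ccc(S(N)(=O)=O)cc4)cc23)c1`: a limit only, > 40000 nM

In a functional assay on A549 cells (Homo sapiens) for antiproliferative activity, read by MTT assay, with a stated time of 72 h (a higher number here means a weaker inhibitor, a lower number a stronger inhibitor), compound 1 gives 14900 nM. For compound 2 in this assay only a limit is recorded, > 40000 nM; this is the limit of > 40000 nM in this assay, at which 1 of the 2 values shown sits. For the measured compounds named here, compound 1 and compound 2 differ in more than one place, so no single step between them is counted, and their two values show only that compound 1 has a number where compound 2 has a limit.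

Compound 3, `NS(=O)(=O)c1ccc(NC(=S)Nc2ccc3ncnc(Nc4cccc(Br)c4)c3c2)cc1`, is compound 2 with bromo in place of ethynyl on an aromatic carbon. Compound 2 stands at the limit, so any step from it can only be judged against that limit. The change is expected to give a step that the limit leaves unreadable from compound 2 to compound 3, no step beyond the scatter. Compound 3 is therefore estimated at 45000 nM, between 15000 nM and 150000 nM, with a fair chance that again only a limit is reported.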

Compound 3, half-maximal inhibitory concentration: 25000 nM
Estimate against measurement, compound 3: 1.8-fold (0.26 log units) above, and the stated range covers the measured number.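

At this aromatic carbon, bromo in place of ethynyl gives an at least 1.6-fold lower number from compound 2 to compound 3 (0.20 log units; that floor lies within the scatter) in this assay. For the compounds shown here, compound 3 gives 25000 nM as a number rather than a limit, so this pair now has one readable end, and the change from 3-ethynylphenyl to 3-bromophenyl can be set against a measured number for the first time. The true size of the step stays unknown because compound 2 is recorded only as a limit: the limit of > 40000 nM in this assay, at which 1 of the 3 values shown sits.

The compounds shown leave open how an amine or a carboxylic acid on this aromatic carbon would read in this assay. They also leave open whether bromo and ethynyl at this place would give a step of similar size on a compound carrying the longer chain of compound 1.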